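The source may hold more compounds than are shown below. What is called first, only, known or untested is meant among the compounds shown, and "the series" means these compounds.

Measured compounds in a functional assay on MIA PaCa-2 cells (Homo sapiens) for cytotoxicity, read by fluorescence, with a stated time of 48 h; on this read-out lower numbers stand for an effect already at smaller amounts and higher numbers for an effect only at larger amounts of compound:

- compound 1, `CC(C)=CCC/C(C)=C/CC/C(C)=C/CSC[C@H](NC(=O)CCCCCN1CCN(C)CC1)C(=O)NC1CCCCCC1`: compound 1 gives 2700 nM
- compound 2, `CC(C)=CCC/C(C)=C/CC/C(C)=C/CSC[C@H](NC(=O)CCCCCN1CCCC1)C(=O)N1CCCCC1`: compound 2 gives 12400 nM
- compound 3, `CC(C)=CCC/C(C)=C/CC/C(C)=C/CSC[C@H](NC(=O)CCCCCN1CCN(C)CC1)C(=O)N1CCCCC1`: compound 3 gives 14300 nM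

Compound 4, `CC(C)=CCC/C(C)=C/CC/C(C)=C/CSC[C@H](NC(=O)CCCCCN1CCCC1)C(=O)NC1CCCCCC1`, has not yet been measured in this assay. It differs from compound 2 in one place, (cycloheptylamino in place of piperidin-1-yl on a carbonyl carbon). The same change has already been measured once in the series, from compound 3 to compound 1, (cycloheptylamino in place of piperidin-1-yl on a carbonyl carbon), where it gave a 5.3-fold lower number from compound 3 to compound 1 (0.72 log units; beyond the scatter). The place lines of the two changes match word for word, so the change from compound 2 to compound 4 is the same change, only on a different core.

The two cores differ by pyrrolidin-1-yl in place of 4-methylpiperazin-1-yl on a saturated chain carbon, five bonds along the chain from a carbonyl carbon. That difference, measured on the piperidin-1-yl carbonyl pair, gave a 1.2-fold higher number from compound 2 to compound 3 (0.06 log units; within the scatter), so compound 2 and compound 3 stand level within the usual scatter, and the change of core does not by itself move the read-out in this assay.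

With one measured instance of the change and a core difference that has proved neutral, the step from compound 2 to compound 4 is expected to be about as large as the measured one: a 5.0-fold lower number from compound 2 to compound 4 (0.70 log units; beyond the scatter), resting on a 5.3-fold lower number from compound 3 to compound 1 (0.72 log units; beyond the scatter). For the measured compounds named here, compound 4 is therefore estimated at 2500 nM in this assay, with a range from 1000 nM to 6500 nM allowing for the single precedent and the scatter of this kind of cell read-out.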

Compound 4, half-maximal effective concentration: 6800 nM
Compound 4: middle estimate off by 2.7-fold (0.43 log units), on the low side; the measured number lies above the stated range.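

Notes on the series, in this assay: cycloheptylamino in place of piperidin-1-yl on a carbonyl carbon does not carry over at one size from one core to the other: the same change on two cores in this assay, a 5.3-fold lower number (0.72 log units; beyond the scatter) from compound 3 to compound 1 and a 1.8-fold lower number (0.26 log units; within the scatter) from compound 2 to compound 4, 2.9-fold (0.46 log units) apart, beyond the scatter of two such steps.

Read the other way round, the swap of pyrrolidin-1-yl for 4-methylpiperazin-1-yl, level on the piperidin-1-yl pair, gives a 2.5-fold higher number from compound 1 to compound 4 (0.40 log units; beyond the scatter) when cycloheptylamino sits on the carbonyl carbon, so the two places do not add up independently in these compounds: the same change on two cores in this assay, a 1.2-fold higher number (0.06 log units; within the scatter) from compound 2 to compound 3 and a 2.5-fold lower number (0.40 log units; beyond the scatter) from compound 4 to compound 1, 2.9-fold (0.46 log units) apart, beyond the scatter of two such steps.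

With pyrrolidin-1-yl on the chain, the carbonyl change gives only a 1.8-fold lower number from compound 2 to compound 4 (0.26 log units; within the scatter) and so cannot be told from the scatter there, which makes the gain on the core of compound 3 a result for that core alone; this single set of four compounds shows that the change depends on the core, but it gives no reason for this and no rule for other groups.

Still open, on these data alone, is whether a morpholin-4-yl or a dimethylamino group at the end of the chain would follow the 4-methylpiperazin-1-yl or the pyrrolidin-1-yl result. Also open, as far as these compounds go, is whether a cyclohexylamino group on the carbonyl carbon would depend on the core in the same way as cycloheptylamino.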